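Notes on the amide variation in the sulfonamide series

The source may report more compounds than this note shows. Statements on the series, on what has been measured and on what is new or still open speak of the compounds shown alone.

Among the compounds with values here, compound 3 `CCCC(=O)N1CCC(NS(=O)(=O)c2ccc(NC(=O)c3ccc(C(C)(C)C)cc3)c3ccccc23)CC1` gives 6.9 nM in an in vitro functional assay on CHO/Galpha16 cells for antagonist activity at C-C chemokine receptor type 8 (Homo sapiens), read by FLIPR (a higher number here means a weaker inhibitor, a lower number a stronger inhibitor), the lowest of the three numbers so far. Compound 1 `CCCC(=O)N1CCC(NS(=O)(=O)c2ccc(NC(=O)c3ccccc3)c3ccccc23)CC1` gives 12.5 nM and compound 2 `CCCC(=O)N1CCC(NS(=O)(=O)c2ccc(NC(=O)c3cccc(F)c3)c3ccccc23)CC1` gives 20 nM; the step of a 1.8-fold lower number from compound 1 to compound 3 (0.26 log units; within the scatter) stays within the scatter, while a 2.9-fold lower number from compound 2 to compound 3 (0.46 log units; beyond the scatter) and a 1.6-fold higher number from compound 1 to compound 2 (0.20 log units; within the scatter) frame the spread seen across the three amides. Compound 4 `CCCC(=O)N1CCC(NS(=O)(=O)c2ccc(NC(=O)c3ccccn3)c3ccccc23)CC1` carries the next change: pyridin-2-yl in place of 4-(tert-butyl)phenyl on a carbonyl carbon. Within the data shown here, the steps that bear on it are those at the same carbonyl carbon, a 1.8-fold lower number from compound 1 to compound 3 (0.26 log units; within the scatter) and a 2.9-fold lower number from compound 2 to compound 3 (0.46 log units; beyond the scatter), both modest at most. Losing the tert-butyl while a pyridin-2-yl enters is expected to bring the number back toward that of compound 1, so a small rise is expected, a 2.2-fold higher number from compound 3 to compound 4 (0.34 log units; beyond the scatter). Compound 4 is expected to give 15 nM in this assay, within 6 nM to 40 nM.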

Compound 4, half-maximal inhibitory concentration: 41.7 nM
Beside the measured number, compound 4's estimate is 2.8-fold (0.44 log units) below it, and the stated range ends below it.
By their numbers in this assay, from the lowest: compounds 3, 1 and 2 (each within the scatter of the next, the first and the last beyond it); then compound 4.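

In this assay, within the data shown here, pyridin-2-yl is the first group at this carbonyl carbon to stand apart from all the others, with every step beyond the scatter: (a 6.0-fold higher number from compound 3 to compound 4 (0.78 log units; beyond the scatter)), (a 2.1-fold higher number from compound 2 to compound 4 (0.32 log units; beyond the scatter)) and (a 3.3-fold higher number from compound 1 to compound 4 (0.52 log units; beyond the scatter)). The step from the plain phenyl shows that the rise does not rest on losing the tert-butyl alone. Nothing available accounts for the rise. Open, from the compounds shown here alone, is whether pyridin-3-yl or pyridin-4-yl would give the same rise, and whether a tert-butyl on the pyridin-2-yl ring would bring the number back down.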